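Lengthening the chain and returning to a sulfur-bearing group

The source may hold more compounds than are shown below. What is called first, only, known or untested is meant among the compounds shown, and "the series" means these compounds.

Of the compounds shown here, three sharing one core have been tested in a functional assay on the whole organism (stomach) for inhibition, with Rattus norvegicus as the target, at a dose of 100 mg/kg by the intraduodenal route; on this read-out higher numbers stand for more inhibition at the one dose given (going by the name of the read-out) and lower numbers for less inhibition. Compound 1 `C/N=C(\S)CCn1nc(-c2ccccc2)ccc1=O` gives 68.2% in this assay. Compound 2 `CNC(=O)CCn1nc(-c2ccccc2)ccc1=O` gives 3.5% and stands lowest of the three; compound 3 `CC(CC(=N)S)n1nc(-c2ccccc2)ccc1=O` gives 15.5%. The step of a number 64.7 percentage points lower from compound 1 to compound 2 (beyond the scatter) shows that swapping the sulfur-containing group for the methylcarbamoyl group cost most of the inhibition, while a number 12 percentage points higher from compound 2 to compound 3 (beyond the scatter) was only modest and a number 52.7 percentage points lower from compound 1 to compound 3 (beyond the scatter) shows that rearranging the chain on the aromatic nitrogen also cost a great deal.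

Compound 4 `C/N=C(/S)CCCCCn1nc(-c2ccccc2)ccc1=O` is not yet measured. It differs from compound 2 by a group of 7 heavy atoms (5 carbon, 1 nitrogen, 1 sulfur; no ring) in place of a group of 4 heavy atoms (2 carbon, 1 nitrogen, 1 oxygen; no ring), on a saturated chain carbon, two bonds along the chain from an aromatic nitrogen. Among the measured compounds shown here, two things pull in opposite directions: the return of a sulfur-bearing group, which in a number 64.7 percentage points lower from compound 1 to compound 2 (beyond the scatter) was worth a large step, and a longer chain, whose effect has no direct precedent, though a number 52.7 percentage points lower from compound 1 to compound 3 (beyond the scatter) warns that altering the chain can hurt. A middling rise is expected, a number 31.5 percentage points higher from compound 2 to compound 4 (beyond the scatter), so compound 4 is estimated at 35%, within 10% to 65%.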

Compound 4, a percentage reported as inhibition, in the whole organism at one dose (the size of the read-out at that dose, not a potency): 92.3%
Compound 4: middle estimate off by 57.3 percentage points, on the low side; measured number above the stated range.
By their numbers in this assay, from the lowest: compound 2; then compound 3; then compound 1; then compound 4.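

In this assay, among the compounds shown here, replacing methylcarbamoyl with the longer sulfur-bearing group of 7 heavy atoms, at this place on the chain, gives a number 88.8 percentage points higher from compound 2 to compound 4 (beyond the scatter), the largest step so far, though it changes both the sulfur-bearing end and the size of the group. With a sulfur-bearing group on both sides, the change still gives a number 24.1 percentage points higher from compound 1 to compound 4 (beyond the scatter), so enlarging this group need not cost inhibition, even though the altered chain of compound 3 shows that a chain change can. Nothing available explains why these changes have such effects.

From the compounds shown here alone, it remains open whether methylcarbamoyl on the same longer chain would match compound 4, which would separate the effect of sulfur from that of length. Also open, going by these compounds, are how a still longer chain, or an amine or carboxylic acid at its end, would behave.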